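Swapping the ring-nitrogen substituent on a thiazolidinone core

This account rests on a few compounds, and the source may have more. Where it says the series, first, only, none or still open, it means among the compounds named here.

The account concerns three compounds tested in a functional assay on HOS-TE85 cells (Homo sapiens) for inhibition, read by CCK-8 assay, with a stated time of 72 h (a higher number here means a weaker inhibitor, a lower number a stronger inhibitor), and one that has not yet been run. Compound 1 `CC(C)(C)c1conc1N1C(=O)CSC1c1cccc(C(=O)NCCCCc2ccccc2)c1` gives only a limit in this assay, namely > 1000 nM. Compound 3 `COc1ccccc1N1C(=O)CSC1C(=O)NCCCCc1ccccc1` likewise stops at a limit, giving > 1000 nM in this assay. Within the data shown here, compound 2 `CC1SC(c2cccc(C(=O)NCCCCc3ccc(Cl)cc3)c2)N(c2cccc(C3CC3)c2)C1=O` is the one member with a number, giving 932 nM in this assay. Compound 1 thus stands at the edge of what this assay can report, and the same is true of compound 3: the limit of > 1000 nM in this assay, at which 2 of the 3 values shown sit.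

Compound 4 `O=C(NCCCCc1ccccc1)c1cccc(C2SCC(=O)N2c2nccs2)c1` differs from compound 1 in one place on the shared core: a group of 5 heavy atoms (3 carbon, 1 nitrogen, 1 sulfur; one five-membered aromatic ring with 2 hetero atoms) in place of a group of 9 heavy atoms (7 carbon, 1 nitrogen, 1 oxygen; one five-membered aromatic ring with 2 hetero atoms), on an amide-type nitrogen in a ring. No measured pair with a single difference exists among these compounds, so the size of this step cannot be read from a neighbour. Compound 1 sits at a limit in this assay. Compound 2 gives 932 nM in this assay, and nothing in the set points toward a strong inhibitor.

Compound 4 is therefore expected to remain weak in this assay, with an estimate of 1500 nM, spanning 500 nM to 5000 nM. The expected step that the limit leaves unreadable from compound 1 to compound 4 is estimated to lie within the scatter, with a fair chance that only a limit is reported again.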

Compound 4, half-maximal inhibitory concentration: > 1000 nM
Compound 4 gave a limit, no number; the forecaster's own chance of this, stated with the estimate: 60%; the middle value is on the limit's open side.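

Among these compounds, compound 4, like compound 1, gives only a limit in this assay, so no step between the two can be read: the limit of > 1000 nM in this assay, at which 3 of the 4 values shown sit. The compounds shown leave open where compound 1 and compound 4 actually lie beyond their limits, and so whether the 1,3-thiazol-2-yl group changes inhibition at all.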